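Sulfonyl aryl swap on a pyrazoline series: expected gain

A few compounds are considered here, and "the series" means these few. Any claim that something is new, unique, unknown or untested is made for them only; others in the source may bear on it.

Compound 1 `Cc1ccc(S(=O)(=O)N2N=C(c3ccc(N4CCN(C)CC4)cc3)CC2c2ccc(N(C)C)cc2)cc1` gives 32.2% in a functional assay on HCC1806 cells (Homo sapiens) for inhibition, read by sulforhodamine B assay, tested at 10 uM; a lower number here means less inhibition, a higher number more inhibition at the concentration tested (going by the name of the read-out). Compound 2 `CN1CCN(c2ccc(C3=NN(S(=O)(=O)c4ccc(F)cc4)C(c4ccc(N(C)C)cc4)C3)cc2)CC1` gives 92.3% in this assay; the change is fluoro in place of methyl on an aromatic carbon, and it moved the read-out a number 60.1 percentage points higher from compound 1 to compound 2 (beyond the scatter). Compound 3 `Cc1ccc(S(=O)(=O)N2N=C(c3ccc(-n4cncn4)cc3)CC2c2ccc(N(C)C)cc2)cc1` gives 27.7% in this assay; it differs from compound 1 by 1H-1,2,4-triazol-1-yl in place of 4-methylpiperazin-1-yl on an aromatic carbon, and the step of a number 4.5 percentage points lower from compound 1 to compound 3 (within the scatter) lies within the usual scatter, so compound 1 and compound 3 read the same here.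

Compound 4 `CN(C)c1ccc(C2CC(c3ccc(-n4cncn4)cc3)=NN2S(=O)(=O)c2ccc(F)cc2)cc1` is not yet measured. It differs from compound 3 by fluoro in place of methyl on an aromatic carbon, the same change seen from compound 1 to compound 2, at a place described in the same words. The two cores differ as described for compound 1 and compound 3. Among the measured compounds shown here, only one measured instance of this change exists, so the expectation rests on it alone: a large rise is expected, a number 47.3 percentage points higher from compound 3 to compound 4 (beyond the scatter), set beside a number 60.1 percentage points higher from compound 1 to compound 2 (beyond the scatter), with a wider band because compound 3 at 27.7% sits on a different core. Compound 4 is estimated to give 75% in this assay, expected between 45% and 95%.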

Compound 4, a percentage reported as inhibition, at one concentration (the size of the read-out at that concentration, not a potency): 24.1%
Beside the measured number, compound 4's estimate is 50.9 percentage points above it; the whole stated range lies above it.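

In this assay the change from (4-methylphenyl)sulfonyl to (4-fluorophenyl)sulfonyl does not carry from one core to the other: the large rise seen with 4-methylpiperazin-1-yl is absent with 1H-1,2,4-triazol-1-yl, where the step reads a number 3.6 percentage points lower from compound 3 to compound 4 (within the scatter), and the two steps differ: the same change on two cores in this assay, a number 60.1 percentage points higher (beyond the scatter) from compound 1 to compound 2 and a number 3.6 percentage points lower (within the scatter) from compound 3 to compound 4, 63.7 percentage points apart, beyond the scatter of two such steps

Read the other way, 1H-1,2,4-triazol-1-yl in place of 4-methylpiperazin-1-yl makes no difference on the methyl pair but reads a number 68.2 percentage points lower from compound 2 to compound 4 (beyond the scatter) on the fluoro pair: the same change on two cores in this assay, a number 4.5 percentage points lower (within the scatter) from compound 1 to compound 3 and a number 68.2 percentage points lower (beyond the scatter) from compound 2 to compound 4, 63.7 percentage points apart, beyond the scatter of two such steps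

So the two changes do not act independently in this set, but a single set of four compounds at one concentration does not show why they depend on each other, or whether the same dependence would appear in a potency measure.

The compounds shown leave open whether the high reading of compound 2 needs the 4-methylpiperazin-1-yl group itself or would also appear with another amine, such as morpholine or piperazine without the methyl. They also leave open whether chloro or methoxy in place of fluoro would pair with that group in the same way.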